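The compounds below may be only part of what the source reports. "The series", "measured", "known", "first", "only" and "open" are said of these compounds alone.

Of the compounds shown here, two have so far been tested in a toxicity assay on the whole organism with Rattus norvegicus as the target, at a dose of 400 mg/kg by the oral route; a higher number here means a stronger effect of the compound at the dose given, a lower number a weaker effect. Compound 1 `Clc1ccc(OCC2=NCCO2)cc1` gives 90%. Compound 2 `Clc1ccccc1OCC1=NCCO1` gives 60%, the lower of the two numbers, separated from compound 1 by a gap beyond the usual scatter. Compound 3 `Fc1ccccc1OCC1=NCCO1` has not yet been measured. It differs from compound 2 in a single place: fluoro in place of chloro on an aromatic carbon. Within the data shown here, no step between two measured compounds is available to show what such a change does here, so the expectation is a small shift, if any, not clearly beyond the scatter. Compound 3 is therefore estimated at 55%, with a range from 35% to 75%, and the expected step is a number 5 percentage points lower from compound 2 to compound 3 (within the scatter).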

Compound 3, a percentage reported as activity, at one dose (the size of the read-out at that dose, not a potency): 80%
Estimate against measurement, compound 3: 25 percentage points below, outside the stated range (above it).
By their numbers in this assay, from the lowest: compound 2; then compounds 3 and 1 (each within the scatter of the next).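

In this assay, fluoro in place of chloro on this aromatic carbon, ortho to a group of 7 heavy atoms, gives a number 20 percentage points higher from compound 2 to compound 3 (beyond the scatter). The identity of the halogen at this place therefore matters, even though one heavy atom simply replaces another and neither group counts a hydrogen-bond donor or acceptor. Nothing available explains the step. As far as these compounds go, how this place responds to something other than a halogen, such as an amine or a carboxylic acid, remains open. So does whether the same swap would give a similar step elsewhere on the ring.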